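From Isopropyl to 4-Fluorophenyl on an Aromatic Nitrogen

This account rests on a few compounds, and the source may have more. Where it says the series, first, only, none or still open, it means among the compounds named here.

Measured in a functional assay on MDA-MB-231 cells (Homo sapiens) for inhibition, read by MTT assay, with a stated time of 48 h; a lower number here means a stronger inhibitor, a higher number a weaker inhibitor:
- compound 1 `CC(C)n1c(S)nnc1CSc1nnc(-c2ccccc2)n1-c1ccccc1`: "not determined" (no result reported)
- compound 2 `Sc1nnc(Sc2nnc(-c3ccccc3)n2-c2ccccc2)n1-c1ccccc1`: 34600 nM

The series offers little to stand on. In this assay compound 1 has the entry "not determined" (no result reported), so no result was reported and the starting point of this step has no number. The only figure available comes from compound 2, at 34600 nM, which is a weak reading on this scale.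

The step leads to compound 3 `Fc1ccc(-n2c(S)nnc2CSc2nnc(-c3ccccc3)n2-c2ccccc2)cc1`, and the change is 4-fluorophenyl in place of isopropyl on an aromatic nitrogen, with the rest of compound 1 left as it is. Among the measured compounds shown here, no measured step shows how this assay responds to a change at this place, so neither the size nor the direction of the step can be read from the data. No clear move is expected, and the working expectation is a reading in the same region as compound 2 at 34600 nM, with a wide margin. Compound 3 is estimated at 30000 nM, with an expected range from 9000 nM to 90000 nM.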

Compound 3, half-maximal inhibitory concentration: 26800 nM
The estimate for compound 3 lay 1.1-fold (0.05 log units) above the measured number, within the range that was stated.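

In this assay, among the compounds shown here, compound 1 stands at "not determined" (no result reported) and compound 3 at 26800 nM, so no step from compound 1 to compound 3 can be read. The compounds shown leave open how 4-fluorophenyl and isopropyl on the aromatic nitrogen compare in this assay. No supporting evidence bears on the reading for compound 3.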